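Removing One Chloro from the Urea Aryl Group

The compounds below may be only part of what the source reports. "The series", "measured", "known", "first", "only" and "open" are said of these compounds alone.

Compound 2 `COc1cc(Cl)cc(-c2nn(-c3cccc(NC(=O)Nc4ccc(Cl)c(C(F)(F)F)c4)c3)cc2-c2ccncc2)c1` gives 16.6% in a functional assay on OVCAR-4 cells (Homo sapiens) for inhibition, read by sulforhodamine B assay, with a stated time of 48 h, tested at 10 uM (a lower number here means a stronger effect, a higher number a weaker effect of the compound at the concentration tested), the second highest of the three numbers measured. Compound 3 `COc1cc(Cl)cc(-c2nn(-c3cccc(NC(=O)Nc4cc(C(F)(F)F)cc(C(F)(F)F)c4)c3)cc2-c2ccncc2)c1` gives 11.9%, within the scatter of compound 2, while compound 1 `COc1cc(Cl)cc(-c2nn(-c3cccc(NC(=O)c4ccc(Cl)c(Cl)c4)c3)cc2-c2ccncc2)c1` gives 58.6%. Among the measured compounds shown here, the only single-place step measured, a number 42 percentage points lower from compound 1 to compound 2 (beyond the scatter), exchanges the whole group on the carbonyl carbon and so does not test one chloro alone. Compound 4 `COc1cc(Cl)cc(-c2nn(-c3cccc(NC(=O)Nc4cccc(C(F)(F)F)c4)c3)cc2-c2ccncc2)c1` differs from compound 2 by hydrogen in place of chloro on an aromatic carbon. For the measured compounds named here, no measured step bears directly on this change; the closest hint is that compound 2 and compound 3, which carry different groups, give numbers within the scatter of each other. A small step, within or near the scatter, is therefore expected: a number 5.4 percentage points higher from compound 2 to compound 4 (within the scatter). Compound 4 is estimated at 22%, between 10% and 40%.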

Compound 4, a percentage reported as activity, at one concentration (the size of the read-out at that concentration, not a potency): 3.28%
Compound 4: the middle estimate sits 18.7 percentage points above what was measured; measured number below the stated range.
By their numbers in this assay, from the lowest: compounds 4, 3 and 2 (each within the scatter of the next, the first and the last beyond it); then compound 1.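

On the aromatic carbon ortho to a trifluoromethyl group, the chloro is not needed in this assay: hydrogen there gives a number 13.3 percentage points lower from compound 2 to compound 4 (beyond the scatter), a stronger effect. Hydrogen in place of trifluoromethyl gives a number 8.6 percentage points lower from compound 3 to compound 4 (within the scatter), so a second group on this aryl ring brings no gain beyond the scatter among these compounds. Among the compounds shown here, replacing the whole 3,4-dichlorophenyl group gives a number 55.3 percentage points lower from compound 1 to compound 4 (beyond the scatter), a wider gap than the one seen with compound 2.

Nothing available explains why losing the chloro strengthens the effect. As far as these compounds go, whether fluoro, methoxy or an amine on that carbon would match hydrogen stays open.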